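Working notes: one chain stereocentre, compound 2 to compound 3

The source may hold more compounds than are shown below. What is called first, only, known or untested is meant among the compounds shown, and "the series" means these compounds.

Measured in a functional assay on the whole organism with Mus musculus as the target; on this read-out higher numbers stand for an effect only at larger amounts of compound and lower numbers for an effect already at smaller amounts:
- Compound 1 `CCCC[C@@](C)(OC)[C@H](O)/C=C/C1[C@H](O)C[C@H](O)[C@@H]1C/C=C\CCCC(=O)OC`: 0.888 mg/kg
- Compound 2 `CCCC[C@](C)(OC)[C@@H](O)/C=C/C1[C@H](O)C[C@H](O)[C@@H]1C/C=C\CCCC(=O)OC`: > 4 mg/kg (a limit)

From the compounds shown here alone, the reading for compound 2 is a limit and not a number, so its true position in this assay remains open. The change under consideration leads to compound 3 `CCCC[C@@](C)(OC)[C@@H](O)/C=C/C1[C@H](O)C[C@H](O)[C@@H]1C/C=C\CCCC(=O)OC`: the two compounds have the same atoms and bonds; at least one stereo element is drawn with a configuration in one of them and without one in the other: 1 of 8 stereo elements differ; a stereocentre at a saturated chain carbon is drawn S in compound 2 and R in compound 3. For the measured compounds named here, the only measured step bearing on this change is an at least 4.5-fold higher number from compound 1 to compound 2 (0.65 log units; beyond the scatter). That step involved two stereocentres at saturated chain carbons, each drawn R in compound 1 and S in compound 2, and the data do not divide its size between them. Going by the values given here, the new change alters one stereocentre at a saturated chain carbon, so it could carry all, part or none of the measured step. A move toward lower numbers in this assay is therefore expected, of modest size and uncertain, and compound 3 may also prove to be reported only as a limit. The expected step is an at least 1.6-fold lower number from compound 2 to compound 3 (0.20 log units; that floor lies within the scatter). For compound 3 the estimated value is 2.5 mg/kg, with an expected range of 0.7 mg/kg to 9 mg/kg.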

Compound 3, dose for half-maximal effect: > 4 mg/kg
Compound 3: a limit, no number (the forecaster's own chance of this, stated with the estimate: 45%); at least 1.6-fold (0.20 log units) between middle value and limit.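

In this assay, changing one stereocentre at a saturated chain carbon is enough on its own for an at least 4.5-fold higher number from compound 1 to compound 3 (0.65 log units; beyond the scatter). From the compounds shown here alone, the earlier step changed two such stereocentres at once and could not be divided between them; this result shows that one of the two alone gives a step beyond the scatter, although its full size stays unknown. Compound 3 stands only as a limit, > 4 mg/kg, and the step from compound 2, which concerns the other stereocentre, cannot be read.

Still open, going by these compounds, is how far compound 2 and compound 3 lie from their limits, and whether the other stereocentre, changed alone with the rest of compound 1 kept as it is, would also move the number in this assay. Also open, on these data alone, is whether this sensitivity to configuration would persist if the methyl ester gave way to a carboxylic acid, or if the methoxy group gave way to a hydroxyl or a longer ether chain.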